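The source may report more compounds than this note shows. Statements on the series, on what has been measured and on what is new or still open speak of the compounds shown alone.

Among the measured compounds shown here, compound 3 `CN1CCC(NC(=O)c2ccc(Nc3ncc(Br)c(NC4CCCC4)n3)cc2)CC1` carries the lowest number of the three compounds measured so far: in a functional assay on HeLa cells (Homo sapiens) for cytotoxicity, read by MTT assay, with a stated time of 48 h (a lower number here means a stronger inhibitor, a higher number a weaker inhibitor), compound 3 gives 900 nM. Its nearest neighbour is compound 2 `CN1CCC(NC(=O)c2ccc(Nc3ncc(Cl)c(NC4CCCC4)n3)cc2)CC1`, which differs only in carrying chloro where compound 3 carries bromo; in this assay compound 2 gives 1500 nM. The step of a 1.7-fold lower number from compound 2 to compound 3 (0.22 log units; within the scatter) is within the scatter. For the measured compounds named here, compound 1 `CN1CCN(c2ccc(Nc3ncc(F)c(NC4CCCC4)n3)cc2)CC1` carries fluoro in place of bromo but differs elsewhere as well, so no single-change step links it to compound 3; in this assay compound 1 gives 20000 nM, a much higher number.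

Compound 4 `CN1CCC(NC(=O)c2ccc(Nc3ncc(F)c(NC4CCCC4)n3)cc2)CC1` has not yet been measured. It differs from compound 3 as follows: fluoro in place of bromo on an aromatic carbon. Going by the values given here, the one measured step that bears on this change, the swap of chloro for bromo, stayed within the scatter, so changing the halogen here has so far moved the number little. The high number of compound 1 cannot be attributed to fluoro alone. Compound 4 is therefore expected to give a modestly higher number, an estimated 2000 nM with a range of 600 nM to 7000 nM, which corresponds to an expected step of a 2.2-fold higher number from compound 3 to compound 4 (0.35 log units; beyond the scatter).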

Compound 4, half-maximal inhibitory concentration: 45500 nM
The estimate for compound 4 lay 23-fold (1.36 log units) below the measured number, outside the stated range (above it).
By their numbers in this assay, from the lowest: compounds 3 and 2 (each within the scatter of the next); then compound 1; then compound 4.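

In this assay, this position on the ring, ortho to a cyclopentylamino group, proves far more sensitive than the swap of chloro for bromo suggested: fluoro in place of bromo brings a 51-fold higher number from compound 3 to compound 4 (1.70 log units; beyond the scatter) and fluoro in place of chloro brings a 30-fold higher number from compound 2 to compound 4 (1.48 log units; beyond the scatter) while chloro and bromo remain within the scatter of each other. With fluoro kept in both compounds, (1-methylpiperidin-4-yl)carbamoyl in place of 4-methylpiperazin-1-yl brings only a 2.3-fold higher number from compound 1 to compound 4 (0.36 log units; beyond the scatter) so here the halogen change is the much larger step. No measurement available here explains why fluoro stands so far from chloro and bromo.

Going by these compounds, it remains open whether a methyl group, a nitrile or an amino group at this position would give a number like that of fluoro or like those of chloro and bromo. On these data alone, it is also open whether bromo would lower the number as sharply when paired with 4-methylpiperazin-1-yl.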